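The compounds below may be only part of what the source reports. "The series", "measured", "known", "first", "only" and "open" are said of these compounds alone.

Compound 2 `O=C1c2ccc(O)c(O)c2O[C@H](c2cccc(O)c2O)[C@H]1O` gives the lowest of the two numbers in a functional assay on RAW264.7 cells (Rattus norvegicus) for inhibition, with RAW264.7 (Mus musculus) as the target, read by Griess assay, with stated times of 2 h and 16 h (on this read-out lower numbers stand for stronger inhibition and higher numbers for weaker inhibition), at 17000 nM. Compound 3 `O=C1c2ccc(O)cc2O[C@H](c2cccc(O)c2O)[C@H]1O` gives 70700 nM in this assay. Compound 1 `COc1ccc2c(c1)C(=O)[C@H](O)[C@@H](c1cccc(O)c1O)O2` reaches only a limit in this assay, reported as > 100000 nM; that is the limit of > 100000 nM in this assay, at which 1 of the 3 values shown sits, and not a number.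

Compound 4 `COc1ccc2c(c1O)O[C@H](c1cccc(O)c1O)[C@@H](O)C2=O` is not yet measured in this assay. Against compound 2 the change is methyl in place of hydrogen on an oxygen on an aromatic ring. Among the measured compounds shown here, one measured step bears on it: a 4.2-fold higher number from compound 2 to compound 3 (0.62 log units; beyond the scatter), where a hydroxy on an aromatic carbon was lost outright and the number rose beyond the scatter. The methylation in compound 4 likewise removes the hydrogen of a hydroxy, though the oxygen stays, so a weakening of similar or somewhat smaller size is expected rather than a gain. Compound 4 is therefore expected to give about 45000 nM in this assay, with a range of 15000 nM to 130000 nM. That estimate amounts to an expected step of a 2.6-fold higher number from compound 2 to compound 4 (0.42 log units; beyond the scatter), with some chance that only a limit is reported.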

Compound 4, half-maximal inhibitory concentration: 49700 nM
Compound 4: the middle estimate sits 1.1-fold (0.04 log units) below what was measured; low and high end bracket the measured number.
By their numbers in this assay, from the lowest: compound 2; then compounds 4 and 3 (each within the scatter of the next). At a limit, above all of these: compound 1.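

The oxygen stays in place in compound 4, yet hydroxy to methoxy on the aromatic ring still gives a 2.9-fold higher number from compound 2 to compound 4 (0.47 log units; beyond the scatter) in this assay and so keeping the oxygen alone does not hold the number of compound 2. The earlier step, a 4.2-fold higher number from compound 2 to compound 3 (0.62 log units; beyond the scatter) and concerning a different hydroxy, showed only the loss of a whole group; compound 4 keeps that hydroxy and carries its change on the other one. Each of the two hydroxy groups on this ring, altered singly, thus raises the number beyond the scatter.

Going by these compounds, whether a longer chain such as ethoxy, or an amine in place of this hydroxy, would follow the same direction stays open. The compounds shown offer no measured property that explains this step.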